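Vinyl for ethyl on the short ester of compound 1

The compounds below may be only part of what the source reports. "The series", "measured", "known", "first", "only" and "open" are said of these compounds alone.

For the measured compounds named here, in a functional assay on WRL68 cells (Homo sapiens) for cytotoxicity, read by MTT assay, with a stated time of 4 h (on this read-out higher numbers stand for weaker inhibition and lower numbers for stronger inhibition), compound 1 (`CCC(=O)OC[C@H]1O[C@@H](O[C@@H]2OC=C(C(=O)OC)[C@H]3C[C@H](OC(C)=O)[C@H](C)[C@@H]23)[C@H](OC(C)=O)[C@@H](OC(C)=O)[C@@H]1OC(C)=O`) gives 2.65 ug/mL and holds the lower of the two numbers so far. Compound 2 (`CCCCCCCCCCCCCC(=O)OC[C@H]1O[C@@H](O[C@@H]2OC=C(C(=O)OC)[C@H]3C[C@H](OC(C)=O)[C@H](C)[C@@H]23)[C@H](OC(C)=O)[C@@H](OC(C)=O)[C@@H]1OC(C)=O`) gives 58.5 ug/mL in this assay and carries undecyl in place of hydrogen on a saturated chain carbon. This only measured step (a 22-fold higher number from compound 1 to compound 2 (1.34 log units; beyond the scatter)) is large. Compound 3 (`C=CC(=O)OC[C@H]1O[C@@H](O[C@@H]2OC=C(C(=O)OC)[C@H]3C[C@H](OC(C)=O)[C@H](C)[C@@H]23)[C@H](OC(C)=O)[C@@H](OC(C)=O)[C@@H]1OC(C)=O`) has vinyl in place of ethyl on a carbonyl carbon. Going by the values given here, the undecyl gain behind compound 2 (58.5 ug/mL) has no counterpart here, so no step beyond the scatter is expected in this assay. The expected step (a 1.1-fold lower number from compound 1 to compound 3 (0.03 log units; within the scatter)) is small. For compound 3 the estimate is 2.5 ug/mL (expected range 1 ug/mL to 7 ug/mL).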

Compound 3, half-maximal inhibitory concentration: "not active" (no number reported)
The entry for compound 3 holds no number; no gap can be computed for the estimate.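

For the compounds shown here, compound 3 is entered as "not active" in this assay, without a number, so no step from compound 1 to compound 3 can be read. Nothing shown explains this result. The compounds shown leave open how far compound 3 lies from compound 1 on this read-out.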